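From 4-methoxyphenyl to 3-methoxyphenyl on the shared core

The compounds below may be only part of what the source reports. "The series", "measured", "known", "first", "only" and "open" are said of these compounds alone.

Of the compounds shown here, two on the shared core have been measured so far. In a functional assay on Jurkat cells (Homo sapiens) for inhibition, read by CCK-8 assay, with a stated time of 48 h (on this read-out higher numbers stand for weaker inhibition of growth and lower numbers for stronger inhibition of growth), compound 1 `Cc1ccc(CNc2nc(Nc3ccc(N4CCN(C)CC4)cn3)ncc2Cl)cc1` gives 12700 nM, and compound 2 `COc1ccc(CNc2nc(Nc3ccc(N4CCN(C)CC4)cn3)ncc2Cl)cc1` gives 12900 nM. Within the data shown here, the single measured step is methoxy in place of methyl on an aromatic carbon, a 1.0-fold higher number from compound 1 to compound 2 (0.01 log units; within the scatter). Among the measured compounds shown here, compound 2 therefore stands level with the only other measured compound, and the two cannot be ranked.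

Compound 3 `COc1cccc(CNc2nc(Nc3ccc(N4CCN(C)CC4)cn3)ncc2Cl)c1` carries 3-methoxyphenyl in place of 4-methoxyphenyl on a saturated chain carbon bound to a nitrogen on an aromatic ring. For the measured compounds named here, no measured step moves a group to another place on a ring, so the evidence for this change is indirect. Going by the values given here, the expectation rests on compound 2 at 12900 nM and on the one exchange measured so far, which stayed small at a 1.0-fold higher number from compound 1 to compound 2 (0.01 log units; within the scatter). The expected step is a 1.2-fold lower number from compound 2 to compound 3 (0.07 log units; within the scatter), with no change beyond the scatter foreseen in this assay. For compound 3 the estimate is 11000 nM, with an expected range of 4500 nM to 25000 nM.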

Compound 3, concentration for 50% growth inhibition: 73400 nM
The estimate for compound 3 lay 6.7-fold (0.82 log units) below the measured number; the measured number lies above the stated range.
By their numbers in this assay, from the lowest: compounds 1 and 2 (each within the scatter of the next); then compound 3.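

In this assay, among these compounds, 3-methoxyphenyl in place of 4-methoxyphenyl gives a 5.7-fold higher number from compound 2 to compound 3 (0.76 log units; beyond the scatter), the first step beyond the scatter. The two groups have the same atoms and differ only in how they are joined, so at this saturated chain carbon bound to a nitrogen on an aromatic ring, the arrangement of the group alone is enough to weaken growth inhibition, which the exchange of methoxy for methyl in the earlier pair did not show. The comparison with 4-methylphenyl points the same way, with a 5.8-fold higher number from compound 1 to compound 3 (0.76 log units; beyond the scatter), so compound 3 stands apart from both earlier compounds, and nothing available on these compounds accounts for the shift.

As far as these compounds go, it remains open whether the weaker inhibition belongs to the 3-methoxyphenyl group alone or extends to other groups of the same pattern, a question that 3-methylphenyl or 3-chlorophenyl would address, with unsubstituted phenyl as the reference. Also open, from the compounds shown here alone, is whether the level shared by compound 1 and compound 2 holds for other groups of the 4-substituted kind, such as 4-chlorophenyl or 4-hydroxyphenyl.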